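A few compounds are considered here, and "the series" means these few. Any claim that something is new, unique, unknown or untested is made for them only; others in the source may bear on it.

Values so far in a toxicity assay on THP-1 cells (Homo sapiens) for inhibition; on this read-out lower numbers stand for higher toxicity in this test and higher numbers for lower toxicity in this test
- compound 1 `Cc1ccccc1C(=O)Nc1ncc(-c2ccccc2)n1C` gives > 100000 nM (a limit of the assay, not a number)
- compound 2 `COc1ccc(-c2cnc(NC(=O)c3ccc(F)cc3)n2-c2ccccc2)cc1` gives 8800 nM (a measured number)

Compound 1 is known only through a limit (the limit of > 100000 nM in this assay, at which 1 of the 2 values shown sits) and so has no exact place on the scale of this assay here. For the measured compounds named here, no measured step connects compound 1 and compound 2, so the series offers no direct guide to size.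

Compound 3 `Cc1ccc(C(=O)Nc2ncc(-c3ccccc3)n2C)cc1` is still unmeasured. Its change is 4-methylphenyl in place of 2-methylphenyl on a carbonyl carbon and amounts to 4-methylphenyl in place of 2-methylphenyl on a carbonyl carbon, with the same atoms joined differently.

The expected move is small: an at least 1.1-fold lower number from compound 1 to compound 3 (0.04 log units; that floor lies within the scatter) is expected to stay within the scatter or to lean slightly toward a lower number, and another limit reading is quite possible. For compound 3 the estimated value in this assay is 90000 nM with an expected range from 30000 nM to 150000 nM on present data.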

Compound 3, half-maximal cytotoxic concentration: > 50000 nM
Compound 3 ended at the assay's limit; the forecaster's own chance of this, stated with the estimate: 65%; the middle value does not contradict the limit.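

In this assay, compound 1 and compound 3 are each known only as a limit, and the step between them, 4-methylphenyl in place of 2-methylphenyl on a carbonyl carbon, cannot be read. The compounds shown leave open whether this change moves the read-out at all.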